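Nitro in Place of Methyl: Expecting Compound 4

A few compounds are considered here, and "the series" means these few. Any claim that something is new, unique, unknown or untested is made for them only; others in the source may bear on it.

Compound 3 `Cc1ccc(-c2c(C#N)c(N)n(/N=C/c3cn(-c4ccccc4)nc3-c3ccccc3)c(=O)c2C#N)cc1` gives > 200 ug/mL in an ADME assay on HeLa cells (Homo sapiens) for cytotoxicity, read by MTT assay; a lower number here means a stronger inhibitor, a higher number a weaker inhibitor; this is a limit of the assay, not a number.
Compound 1 `N#Cc1c(-c2ccccc2)c(C#N)c(=O)n(/N=C/c2cn(-c3ccccc3)nc2-c2ccccc2)c1N` gives > 200 ug/mL in this assay; this too is a limit.
Compound 2 `N#Cc1c(-c2ccccc2O)c(C#N)c(=O)n(/N=C/c2cn(-c3ccccc3)nc2-c2ccccc2)c1N` gives > 200 ug/mL in this assay; again a limit.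

Compound 3 therefore stands at the top of what has been seen, together with the other two compounds, because of the limit of > 200 ug/mL in this assay, at which 3 of the 3 values shown sit. Going by these compounds, none of the three shares a readable step: a step that the two limits leave unreadable from compound 1 to compound 2, a step that the two limits leave unreadable from compound 1 to compound 3 and a step that the two limits leave unreadable from compound 2 to compound 3 each join two limits, so their sizes are unknown.

Compound 4 `N#Cc1c(-c2ccccc2[N+](=O)[O-])c(C#N)c(=O)n(/N=C/c2cn(-c3ccccc3)nc2-c2ccccc2)c1N` differs from compound 3 in one place: 2-nitrophenyl in place of 4-methylphenyl on an aromatic carbon. The shared core, the hydrazone-linked pyrazole and the two cyano groups stay as they are.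

Among the measured compounds shown here, no measured step bears on this change in a readable way, since every value so far is a limit. What can be said is that each change tried on this ring has left the compound at the limit of this assay.

Compound 4 is expected to give about 200 ug/mL, within 100 ug/mL to 400 ug/mL, most likely again as a limit rather than a number. That expectation amounts to a step of a number no higher from compound 3 to compound 4 (the limit leaves the size open).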

Compound 4, half-maximal inhibitory concentration: > 200 ug/mL
Compound 4 ended at the assay's limit; the forecaster's own chance of this, stated with the estimate: 75%; the middle value lies on the limit itself.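

Compound 4 gives > 200 ug/mL in this assay, which is a limit and not a number. Its steps from compound 1, compound 2 and compound 3 cannot be read, since each joins two limits: the limit of > 200 ug/mL in this assay, at which 4 of the 4 values shown sit.

The compounds shown leave open how large a difference, if any, each of these changes makes in this assay.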